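A Fluorophenyl Swap on an Inactive Dichlorophenyl Scaffold

The source may report more compounds than this note shows. Statements on the series, on what has been measured and on what is new or still open speak of the compounds shown alone.

Compound 1 `C=CCn1c(=O)/c(=C\c2ccc(Cl)c(Cl)c2)[nH]c(=O)/c1=C\c1ccccc1OC` was tested in a functional assay on HeLa cells (Homo sapiens) for cytotoxicity, read by CCK-8 assay, with a stated time of 72 h (a higher number here means a weaker inhibitor, a lower number a stronger inhibitor), where compound 1 gives "not active" (no number reported), so no single number places it on a scale. Its close relative compound 2 `C=CCn1c(=O)/c(=C\c2ccc(Cl)c(Cl)c2)[nH]c(=O)/c1=C\c1ccccc1` gives "not active" (no number reported) in this assay, again without a number. Going by the values given here, only compound 3 `COc1ccccc1/C=c1/[nH]c(=O)/c(=C\c2nc[nH]c2C(C)(C)C)[nH]c1=O` yields a number, giving 80 nM in this assay; it differs from compound 1 in more than one place, so it offers no single step. Compound 4 `C=CCn1c(=O)/c(=C\c2ccccc2F)[nH]c(=O)/c1=C\c1ccccc1OC` keeps the core of compound 1 and changes one group: 2-fluorophenyl in place of 3,4-dichlorophenyl on a double-bonded chain carbon bound to an aromatic carbon. Among the compounds with values here, no measured step covers this change, and because compound 1 gives "not active" (no number reported) no direction can be set from numbers. The study expects compound 4 to stay weak in this assay, possibly with no reportable number. The estimate for compound 4 is 20000 nM, spanning 3000 nM to 100000 nM.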

Compound 4, half-maximal inhibitory concentration: 45000 nM
The estimate for compound 4 lay 2.3-fold (0.35 log units) below the measured number; the measured number falls inside the stated range.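

Going by these compounds alone, compound 1 has no single number in this assay, so no step to compound 4 can be read. How far the 2-fluorophenyl swap shifts potency stays open, and nothing shown offers an explanation for the result.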